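Replacing the amino group of compound 2 by methyl

A few compounds are considered here, and "the series" means these few. Any claim that something is new, unique, unknown or untested is made for them only; others in the source may bear on it.

Compound 2 `N#Cc1c(N)cccc1NC(=O)C(=O)O` gives 21.2% in a functional assay on the whole organism for inhibition, with Rattus norvegicus as the target, at a dose of 1 mg/kg by the oral route (a higher number here means more inhibition at the dose given (going by the name of the read-out), a lower number less inhibition), the lowest of the three numbers measured: compound 1 `CN(C)c1cccc(NC(=O)C(=O)O)c1C#N` gives 54.7% and compound 3 `CCN(C)c1cccc(NC(=O)C(=O)O)c1C#N` gives 56.3%. Compound 4 `Cc1cccc(NC(=O)C(=O)O)c1C#N` differs from compound 2 by methyl in place of amino on an aromatic carbon. Among the compounds with values here, two measured steps bear on this change, both involving the amino group on an aromatic carbon: a number 33.5 percentage points lower from compound 1 to compound 2 (beyond the scatter) and a number 35.1 percentage points higher from compound 2 to compound 3 (beyond the scatter). The step of a number 1.6 percentage points higher from compound 1 to compound 3 (within the scatter) shows that the size of the alkyl groups on that nitrogen mattered little. Neither measured step places a methyl on that aromatic carbon, so the outcome for compound 4 is uncertain, though both steps leave the amino compound at the low end. For compound 4 a moderate rise is expected, a number 18.8 percentage points higher from compound 2 to compound 4 (beyond the scatter), giving an estimated 40% with a range of 15% to 65% in this assay.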

Compound 4, a percentage reported as inhibition, in the whole organism at one dose (the size of the read-out at that dose, not a potency): 32.3%
For compound 4 the middle estimate is 7.7 percentage points above the measured one, and the stated range covers the measured number.
By their numbers in this assay, from the lowest: compound 2; then compound 4; then compounds 1 and 3 (each within the scatter of the next).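

In this assay, methyl gives more inhibition than amino on this aromatic carbon: a number 11.1 percentage points higher from compound 2 to compound 4 (beyond the scatter). Methyl still falls short of both tertiary amino groups: a number 22.4 percentage points lower from compound 1 to compound 4 (beyond the scatter) and a number 24 percentage points lower from compound 3 to compound 4 (beyond the scatter). The order at this position is therefore not a simple split between nitrogen and carbon substituents, since amino and methyl both stand below dimethylamino and ethyl(methyl)amino.

Going by these compounds, whether methoxy, ethyl or a cyclic amine such as pyrrolidine would reach the level of compound 1 remains open. Nothing available explains this order.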